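The compounds below may be only part of what the source reports. "The series", "measured", "known", "first", "only" and "open" are said of these compounds alone.

Of the compounds shown here, two have been measured so far in an ADME assay on L02 cells (Homo sapiens) for inhibition, read by CCK-8 assay, with a stated time of 48 h; on this read-out higher numbers stand for weaker inhibition of growth and lower numbers for stronger inhibition of growth. Compound 1 (`Cc1ccccc1Nc1nc(Nc2ccc(N3CCN(C(=O)OC(C)(C)C)CC3)cc2)ncc1Cl`) gives 1750 nM and compound 2 (`CN1CCN(c2ccc(Nc3ncc(Cl)c(NCc4ccc(F)cc4)n3)nc2)CC1`) gives 39700 nM as the higher of the two numbers, a gap beyond the scatter. Going by the values given here, these two differ in more than one place, so no single-place step is available to size the next change. Compound 3 (`CCc1ccc(Nc2nc(Nc3ccc(N4CCN(C)CC4)cn3)ncc2Cl)cc1`) has 4-ethylphenyl in place of 4-fluorobenzyl on a nitrogen on an aromatic ring. A move to a lower number, beyond the scatter, is expected. Among the compounds with values here, the expectation leans on compound 1 (1750 nM), the one measured compound without a benzyl group on that nitrogen, although it also differs from compound 3 elsewhere. The estimated change is a 6.6-fold lower number from compound 2 to compound 3 (0.82 log units; beyond the scatter) in this direction. The expected value for compound 3 is 6000 nM with an estimated range of 1500 nM to 25000 nM in this assay.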

Compound 3, concentration for 50% growth inhibition: 12100 nM
Beside the measured number, compound 3's estimate is 2.0-fold (0.30 log units) below it, and the stated range covers the measured number.
By their numbers in this assay, from the lowest: compound 1; then compound 3; then compound 2.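

In this assay, going by these compounds alone, placing 4-ethylphenyl in place of 4-fluorobenzyl on a nitrogen on an aromatic ring gives a 3.3-fold lower number from compound 2 to compound 3 (0.52 log units; beyond the scatter), a modest move and the only single-place comparison available so far. It shows that the number responds to the group on this nitrogen, even though both groups have 8 heavy atoms and one six-membered aromatic ring of carbon only. Nothing measured here bears on the reason for the step.

As far as these compounds go, the change alters the link to the ring and the substituent on it in a single move, so the share of each remains open. A 4-fluorophenyl group or a 4-ethylbenzyl group on the same nitrogen would separate the two, and an amine or a carboxylic acid on that ring would test whether the response extends beyond carbon and fluorine substituents.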